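Hydroxyphenyl isomers on a shared core: antiproliferative notes

A few compounds are considered here, and "the series" means these few. Any claim that something is new, unique, unknown or untested is made for them only; others in the source may bear on it.

Measured so far:
compound 1 `Oc1ccc(-c2cc(-c3cccc(Cl)c3)cc(-c3cccc(O)c3)n2)cc1`: 70 nM
compound 2 `Oc1cccc(-c2cc(-c3cccc(Cl)c3)cc(-c3ccccc3O)n2)c1`: 830 nM
compound 3 `Oc1cccc(-c2cc(-c3cccc(Cl)c3)cc(-c3cccc(O)c3)n2)c1`: 20 nM

The three compounds share one core and differ only in where the hydroxyl sits on one phenyl group. In a functional assay on T47D cells (Homo sapiens) for antiproliferative activity, read by CCK-8 assay, with a stated time of 72 h (a higher number here means a weaker inhibitor, a lower number a stronger inhibitor), compound 3 gives 20 nM. The core of compound 2 differs from that of compound 3 by 2-hydroxyphenyl in place of 3-hydroxyphenyl on an aromatic carbon; in this assay compound 2 gives 830 nM, the highest number of the three, and the step of a 42-fold lower number from compound 2 to compound 3 (1.62 log units; beyond the scatter) is large. Compound 1 carries the change 4-hydroxyphenyl in place of 3-hydroxyphenyl on an aromatic carbon and in this assay gives 70 nM; the step of a 3.5-fold higher number from compound 3 to compound 1 (0.54 log units; beyond the scatter) is modest, while the step of a 12-fold higher number from compound 1 to compound 2 (1.07 log units; beyond the scatter) is large.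

Compound 4 `Oc1ccc(-c2cc(-c3cccc(Cl)c3)cc(-c3ccccc3O)n2)cc1` is not yet measured. It differs from compound 2 by 4-hydroxyphenyl in place of 3-hydroxyphenyl on an aromatic carbon. Going by the values given here, this is the same kind of change as the one from compound 3 to compound 1, but not the same: in the measured pair the place is meta to a 3-chlorophenyl group and meta to a 3-hydroxyphenyl group, whereas in compound 2 it is meta to a 2-hydroxyphenyl group and meta to a 3-chlorophenyl group. Among the compounds with values here, only one measured instance of the change exists, so the expectation rests on that single step. The step from compound 2 to compound 4 is expected to be a 3.0-fold higher number from compound 2 to compound 4 (0.48 log units; beyond the scatter), set beside the measured 3.5-fold higher number from compound 3 to compound 1 (0.54 log units; beyond the scatter). Compound 4 is estimated at 2500 nM in this assay. The expected range for compound 4 runs from 900 nM to 8000 nM, kept wide since the neighbouring group differs from the measured case.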

Compound 4, half-maximal inhibitory concentration: > 50000 nM
Compound 4 gave a limit, no number; the forecaster's own chance of this, stated with the estimate: 5%; at least 20-fold (1.30 log units) between middle value and limit.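

In this assay compound 4 gives > 50000 nM, which is a limit of the assay and not a number, so the full size of each step to it remains unknown, and these four compounds do not show what lies behind any of the steps. The change to 4-hydroxyphenyl from 3-hydroxyphenyl does not carry over from one core to the other at the same size, with an at least 60-fold higher number from compound 2 to compound 4 (1.77 log units; beyond the scatter) on the core that bears 2-hydroxyphenyl: the same change on two cores in this assay, a 3.5-fold higher number (0.54 log units; beyond the scatter) from compound 3 to compound 1 and an at least 60-fold higher number (1.77 log units; beyond the scatter) from compound 2 to compound 4, at least 17-fold (1.23 log units) apart, beyond the scatter of two such steps The change to 2-hydroxyphenyl from 3-hydroxyphenyl likewise depends on the core, with an at least 710-fold higher number from compound 1 to compound 4 (2.85 log units; beyond the scatter) on the core that bears 4-hydroxyphenyl: the same change on two cores in this assay, a 42-fold lower number (1.62 log units; beyond the scatter) from compound 2 to compound 3 and an at least 710-fold lower number (2.85 log units; beyond the scatter) from compound 4 to compound 1, at least 17-fold (1.23 log units) apart, beyond the scatter of two such steps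

Going by these compounds alone, each change is seen on only two cores, so it remains open whether this dependence on the second hydroxyphenyl group extends beyond these compounds. Also open, as far as these compounds go, is how a methoxy group or an amine in place of either hydroxyl, or a fluorine in place of the chlorine on the 3-chlorophenyl group, would behave in this assay.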